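Working notes on two benzyl ethers and one further variant

The compounds below may be only part of what the source reports. "The series", "measured", "known", "first", "only" and "open" are said of these compounds alone.

compound 1 `Cc1ccccc1COc1nc(N)nc2[nH]nnc12`: 470 nM
compound 2 `Nc1nc(OCc2cccc(F)c2)c2nn[nH]c2n1`: 40 nM

In an assay on isolated protein for inhibition of Myeloperoxidase (Homo sapiens), read by fluorescence, with stated times of 10 min, 30 s and 5 min (on this read-out higher numbers stand for weaker inhibition and lower numbers for stronger inhibition), compound 2 gives 40 nM, the lower of the two numbers. Compound 1 gives 470 nM, a gap well beyond the scatter, so compound 2 stands as the stronger inhibitor of the pair. Compound 3 `Nc1nc(OCc2cccc(OC(F)F)c2)c2nn[nH]c2n1` differs from compound 2 by difluoromethoxy in place of fluoro on an aromatic carbon. Within the data shown here, no measured pair shows this change, so its effect in this assay is open. For compound 3 a small weakening, close to the scatter, is expected: a 2.0-fold higher number from compound 2 to compound 3 (0.30 log units; within the scatter). Compound 3 is estimated at 80 nM, within a range from 25 nM to 250 nM.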

Compound 3, half-maximal inhibitory concentration: 200 nM
For compound 3 the middle estimate is 2.5-fold (0.40 log units) below the measured one; the measured number falls inside the stated range.
By their numbers in this assay, from the lowest: compound 2; then compound 3; then compound 1.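

On the aromatic carbon meta to a large group, difluoromethoxy in place of fluoro gives a 5.0-fold higher number from compound 2 to compound 3 (0.70 log units; beyond the scatter) in this assay. This position therefore responds to the change beyond the scatter, while compound 3 keeps a nanomolar number with the larger group in place. Among these compounds, it is the first single-place step, and it runs towards weaker inhibition.

As far as these compounds go, how an amine or a carboxylic acid on the same aromatic carbon would read remains open. No measurement shown explains the rise in the number from fluoro to difluoromethoxy.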